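Chloro for methoxy on a thiazoline hydrazide

The source may report more compounds than this note shows. Statements on the series, on what has been measured and on what is new or still open speak of the compounds shown alone.

Compound 1 `COc1ccc(-c2cs/c(=N\NC(=O)c3ccc(O)cc3)n2-c2ccc(OC)cc2OC)cc1` gives in a functional assay on PC-3 cells (Homo sapiens) for cytotoxicity, read by sulforhodamine B assay, with a stated time of 48 h (on this read-out higher numbers stand for lower toxicity in this test and lower numbers for higher toxicity in this test), only a limit, < 100000 nM.
Compound 2 `O=C(c1ccc(O)cc1)n1nc(-c2c(Cl)cccc2Cl)sc1=S` gives in this assay only a limit, < 100000 nM.
Compound 3 `Cc1ccc(-c2cs/c(=N\NC(=O)c3ccc(O)cc3)n2-c2c(C)cccc2C)cc1` gives in this assay only a limit, < 100000 nM.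

Compound 1 therefore has no number of its own in this assay; it sits at the limit of the assay, and the same is true of every measured compound shown here, as the limit of < 100000 nM in this assay, at which 3 of the 3 values shown sit, records. Within the data shown here, there is no pair of measured compounds that differ in a single place, so no measured step can be read from these data.

Compound 4 `COc1ccc(-n2c(-c3ccc(Cl)cc3)cs/c2=N\NC(=O)c2ccc(O)cc2)c(OC)c1` departs from compound 1 by chloro in place of methoxy on an aromatic carbon. With only limits to build on, there is no basis for expecting a step beyond the usual scatter in this assay, in either direction; the step from compound 1 to compound 4 is expected to be a step that the limit leaves unreadable from compound 1 to compound 4. Compound 4 is accordingly estimated at 40000 nM, within a range from 8000 nM to 100000 nM, and it is expected that the assay may again report only a limit for compound 4 rather than a number.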

Compound 4, concentration lethal to 50% of the cells: < 100000 nM
Compound 4 ended at the assay's limit; the forecaster's own chance of this, stated with the estimate: 65%; the middle value is on the limit's open side.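

Compound 1 and compound 4 both give only a limit in this assay, so no step can be read for chloro in place of methoxy. The compounds shown leave open where any true value lies and whether this change matters at all, since every result stands at the same limit: the limit of < 100000 nM in this assay, at which 4 of the 4 values shown sit.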